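A few compounds are considered here, and "the series" means these few. Any claim that something is new, unique, unknown or untested is made for them only; others in the source may bear on it.

Measured compounds:
- Compound 1 `O=C(NCc1ccccc1)N(Cc1ccccn1)n1cnnc1` gives 22000 nM in a functional assay on A549 cells (Homo sapiens) for cytotoxicity, read by MTT assay, with a stated time of 48 h; on this read-out higher numbers stand for weaker inhibition and lower numbers for stronger inhibition.
- Compound 2 `CCCCCCCCCNC(=O)N(Cc1cc(OC)ccc1OC)n1cnnc1` gives > 50000 nM in this assay; this is a limit of the assay, not a number (the limit of > 50000 nM in this assay, at which 1 of the 3 values shown sits).
- Compound 3 `Cc1ccsc1CN(C(=O)Nc1ccc(Cl)c(C(F)(F)F)c1)n1cnnc1` gives 26200 nM in this assay.

All three compounds share one core, and each carries a urea-type linker with different groups on either side. Among the two compounds for which a number is known, compound 1 and compound 3 sit close together, and the gap between them is within the usual scatter of repeated measurements, so no order can be read from it. Compound 2 gives only a limit.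

Compound 4 `O=C(NC1CCCCC1)N(Cc1ccccn1)n1cnnc1` has not yet been measured in this assay. It differs from compound 1 in a single place: cyclohexyl in place of benzyl on an amide-type nitrogen. Within the data shown here, this change, cyclohexyl in place of benzyl on an amide-type nitrogen, is a step for which no measured pair exists here, so the direction is open. With the numbers known for compound 1 and compound 3 so close, no step beyond the scatter is expected in either direction. The expected change from compound 1 to compound 4 is a 1.1-fold higher number from compound 1 to compound 4 (0.06 log units; within the scatter), which is estimated as no change beyond the scatter. Compound 4 is expected to give about 25000 nM, with a range from 8000 nM to 80000 nM.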

Compound 4, half-maximal inhibitory concentration: > 50000 nM
Compound 4 ended at the assay's limit (the forecaster's own chance of this, stated with the estimate: 30%); middle value at least 2.0-fold (0.30 log units) from the limit.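

In this assay, among these compounds, cyclohexyl in place of benzyl on an amide-type nitrogen gives an at least 2.2-fold higher number from compound 1 to compound 4 (0.35 log units; beyond the scatter), and this is the first measured pair at this position. It shows that the position is not indifferent: with the rest of compound 1 kept, a six-membered aromatic ring of carbon only gives way to a six-membered non-aromatic ring of carbon only, and the weaker inhibition goes beyond the scatter, even though the two groups match in hydrogen-bond donors, hydrogen-bond acceptors and net charge. The true size of the step stays unknown because compound 4 sits at a limit of the assay, not at a number: the limit of > 50000 nM in this assay, at which 2 of the 4 values shown sit.

The compounds shown leave open which part of benzyl matters, its aromatic ring or the carbon that joins that ring to the nitrogen, and a phenyl group or a cyclohexylmethyl group on this nitrogen would help to tell these apart. Also open, going by these compounds, is whether a ring is needed here at all, a question that a short chain such as butyl on the same nitrogen could address.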